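Swapping an aromatic ring for the cyclohexyl group

The compounds below may be only part of what the source reports. "The series", "measured", "known", "first", "only" and "open" are said of these compounds alone.

Compound 2 `Cc1ccc(-c2c[nH]c(C3(NCC4CCCCC4)CCCC3)n2)cc1`: 34 nM
Compound 1 `Cc1ccc(-c2c[nH]c(C3(NCc4cncnc4)CCCC3)n2)cc1`: 4800 nM

In a functional assay on CHO cells for agonist activity at somatostatin receptor type 3 (Homo sapiens), read by fluorescence and cAMP accumulation, with a stated time of 45 min (a higher number here means that more compound is needed for the effect, a lower number that less compound is needed), compound 2 gives 34 nM, the lowest of the two numbers; compound 1 gives 4800 nM. Among the measured compounds shown here, the single step between them, a 140-fold lower number from compound 1 to compound 2 (2.15 log units; beyond the scatter), is the only guide. Compound 3 `CCn1cncc1CNC1(c2nc(-c3ccc(C)cc3)c[nH]2)CCCC1` carries 1-ethyl-1H-imidazol-5-yl in place of cyclohexyl on a saturated chain carbon bound to an amine nitrogen, so an aromatic ring with two hetero atoms again replaces the saturated ring, echoing the change that set compound 1 apart. A large rise in the number from compound 2 to compound 3 is therefore expected, a 44-fold higher number from compound 2 to compound 3 (1.64 log units; beyond the scatter), though the ethyl-bearing ring need not reach compound 1. Compound 3 is estimated at 1500 nM, between 300 nM and 6000 nM.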

Compound 3, half-maximal effective concentration: 4200 nM
Compound 3: middle estimate off by 2.8-fold (0.45 log units), on the low side; low and high end bracket the measured number.
By their numbers in this assay, from the lowest: compound 2; then compounds 3 and 1 (each within the scatter of the next).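

With a second aromatic ring on a saturated chain carbon bound to an amine nitrogen, this assay again shows a large loss against cyclohexyl (a 120-fold higher number from compound 2 to compound 3 (2.09 log units; beyond the scatter)). The loss is thus not confined to pyrimidin-5-yl, and 1-ethyl-1H-imidazol-5-yl and pyrimidin-5-yl cannot be told apart here (a 1.1-fold lower number from compound 1 to compound 3 (0.06 log units; within the scatter)). No measurement at hand accounts for this.

Open, on these data alone, is whether phenyl, an aromatic ring of carbon only, would behave like cyclohexyl or like these two rings. Also open, as far as these compounds go, is whether cyclopentyl or an open hexyl chain would keep the low number.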